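Urea to amide at the shared core: compound 4

The compounds below may be only part of what the source reports. "The series", "measured", "known", "first", "only" and "open" are said of these compounds alone.

Compounds measured so far:
compound 1 `O=C(Nc1cccc(-n2cc(-c3ccncc3)c(-c3cc(O)cc(Cl)c3)n2)c1)Nc1ccc(Cl)c(C(F)(F)F)c1` — 95%
compound 2 `COc1cc(Cl)cc(-c2nn(-c3cccc(NC(=O)Nc4ccc(Cl)c(C(F)(F)F)c4)c3)cc2-c2ccncc2)c1` — 94%
compound 3 `COc1cc(Cl)cc(-c2nn(-c3cccc(NC(=O)Nc4cc(C(F)(F)F)cc(C(F)(F)F)c4)c3)cc2-c2ccncc2)c1` — 101%

In a functional assay on PC-3 cells (Homo sapiens) for inhibition, read by sulforhodamine B assay, with a stated time of 48 h, tested at 0.01 uM (on this read-out lower numbers stand for a stronger effect and higher numbers for a weaker effect at the one concentration tested), compound 1 gives 95%, compound 2 gives 94% and compound 3 gives 101%. Compound 2 has the lowest number of the three, yet its nearest neighbour is compound 1 and its furthest is compound 3, and both of those gaps lie within the scatter, so no order among them can be claimed.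

Among the compounds with values here, the one measured step, a number 1 percentage points lower from compound 1 to compound 2 (within the scatter), concerns the oxygen on the aromatic ring and leaves the read-out unchanged beyond the scatter. Compound 4 `COc1cc(Cl)cc(-c2nn(-c3cccc(NC(=O)c4cccc(C(F)(F)F)c4)c3)cc2-c2ccncc2)c1` differs from compound 2 elsewhere: 3-(trifluoromethyl)phenyl in place of (4-chloro-3-(trifluoromethyl)phenyl)amino on a carbonyl carbon. Within the data shown here, no measured step touches this part of the molecule, so nothing in the data shows a change there to move the read-out. Since all three measured compounds sit close together, compound 4 is expected to behave alike, with a step of a number 3 percentage points higher from compound 2 to compound 4 (within the scatter) that is no larger than the scatter. Compound 4 is therefore estimated at 97%, in the range 85% to 105%.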

Compound 4, a percentage reported as activity, at one concentration (the size of the read-out at that concentration, not a potency): 94%
Beside the measured number, compound 4's estimate is 3 percentage points above it; low and high end bracket the measured number.
By their numbers in this assay, from the lowest: compounds 2, 4, 1 and 3 (each within the scatter of the next).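

In this assay, within the data shown here, the step of no change at the digits printed from compound 2 to compound 4 (within the scatter) is the first measured change on this carbonyl carbon, where 3-(trifluoromethyl)phenyl enters in place of (4-chloro-3-(trifluoromethyl)phenyl)amino. The exchange removes the amino nitrogen, with its hydrogen-bond donor, and the chlorine together, and the read-out at this one concentration does not register the loss of the two as a pair, though this single step cannot tell their contributions apart. No available evidence bears on why the number stays where it is.

The compounds shown leave open whether any change on this carbonyl carbon can move the read-out beyond the scatter. Going by these compounds, a group such as a carboxylic acid or an aliphatic amine on the phenyl ring in place of trifluoromethyl remains untested among them.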